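A few compounds are considered here, and "the series" means these few. Any claim that something is new, unique, unknown or untested is made for them only; others in the source may bear on it.

Of the compounds shown here, three sharing one core have been measured in a functional assay on B16-F10 cells (Mus musculus) for antiproliferative activity, read by MTT assay, with a stated time of 48 h; on this read-out higher numbers stand for weaker inhibition and lower numbers for stronger inhibition. Compound 1 `COc1ccc(/C=C/c2cc(OC)cc(OC)c2/C=C/C(=O)c2cccc(OC)c2)cc1` gives 4.3 ug/mL. Compound 2 `COc1ccc(/C=C/c2cc(OC)cc(OC)c2/C=C/C(=O)c2cccc(Br)c2)cc1` gives 5.1 ug/mL, and compound 3 `COc1ccc(/C=C/c2cc(OC)cc(OC)c2/C=C/C(=O)c2ccc(Br)cc2)cc1` gives 6.5 ug/mL. Compound 1 has the lowest of the three numbers, but the gaps to the others are small: a 1.2-fold higher number from compound 1 to compound 2 (0.07 log units; within the scatter), and a 1.5-fold higher number from compound 1 to compound 3 (0.18 log units; within the scatter). The remaining step, a 1.3-fold higher number from compound 2 to compound 3 (0.11 log units; within the scatter), is likewise small. None of these differences exceeds the scatter of repeated measurements, so the three compounds cannot be ranked against one another on this evidence.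

Compound 4 `COc1ccc(/C=C/c2cc(OC)cc(OC)c2/C=C/C(=O)c2ccc(C(F)(F)F)cc2)cc1` has not yet been measured. It differs from compound 1 in a single place: 4-(trifluoromethyl)phenyl in place of 3-methoxyphenyl on a carbonyl carbon. The step bearing most directly on this change is the one in which 4-bromophenyl replaced 3-methoxyphenyl on the carbonyl carbon, and there the number barely moved. The swap of 3-bromophenyl for 4-bromophenyl on the same carbonyl carbon was equally uneventful. On that basis the expected step of a 1.3-fold higher number from compound 1 to compound 4 (0.11 log units; within the scatter) is none beyond the scatter, with only a slight lean toward a higher number. Compound 4 is therefore estimated at 5.5 ug/mL, within a range from 3 ug/mL to 10 ug/mL.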

Compound 4, half-maximal inhibitory concentration: 4.3 ug/mL
The estimate for compound 4 lay 1.3-fold (0.11 log units) above the measured number, within the range that was stated.
By their numbers in this assay, from the lowest: compounds 1, 4, 2 and 3 (each within the scatter of the next).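

Placing 4-(trifluoromethyl)phenyl on the carbonyl carbon in place of 3-methoxyphenyl gives no change at the digits printed from compound 1 to compound 4 (within the scatter) even though the entering group has more heavy atoms, contains fluorine and lacks the hydrogen-bond acceptor of the group it replaces. Comparison with the two bromo compounds tells the same story: trifluoromethyl in place of bromo gives a 1.5-fold lower number from compound 3 to compound 4 (0.18 log units; within the scatter) and 4-(trifluoromethyl)phenyl in place of 3-bromophenyl gives a 1.2-fold lower number from compound 2 to compound 4 (0.07 log units; within the scatter) so this third kind of substituent, after methoxy and bromo, also leaves the number inside the scatter and the four compounds still cannot be ranked. No measurement shown here accounts for this flat result.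

The compounds shown leave open whether any group on the carbonyl carbon can move the number beyond the scatter, since every one carries a phenyl ring bearing methoxy, bromo or trifluoromethyl, and a phenyl ring bearing an amine or a carboxylic acid, or a plain alkyl chain in place of the ring, could behave differently. They also leave open what happens when the rest of the shared core changes, including its methoxy groups, which are the same in all four compounds.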